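A few compounds are considered here, and "the series" means these few. Any claim that something is new, unique, unknown or untested is made for them only; others in the source may bear on it.

Measured compounds:
- compound 1, `CC(C)Cc1ccc2c(NCCCNCc3ccco3)ccnc2c1`: 9.47
- compound 2, `COc1ccc(F)cc1CNCCCNc1ccnc2cc(CC(C)C)ccc12`: 9.47
- compound 3, `COc1ccc(Oc2ccc3c(NCCCNCc4ccco4)ccnc3c2)cc1`: 9.28

In a physicochemical assay for acid dissociation, compound 1 stands level with compound 2 at the digits printed, and the two together hold the highest numbers of the three; compound 3 sits furthest from compound 1, though still within the scatter. Two single changes to compound 1 have been measured. Putting 5-fluoro-2-methoxyphenyl in place of furan-2-yl on a saturated chain carbon bound to an amine nitrogen gave no change at the digits printed from compound 1 to compound 2 (within the scatter). Putting 4-methoxyphenoxy in place of isobutyl on an aromatic carbon gave a number 0.19 log units lower from compound 1 to compound 3 (within the scatter).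

Compound 4, `FC(F)(F)c1cccc(Cc2ccc3c(NCCCNCc4ccco4)ccnc3c2)c1`, is not yet measured. It differs from compound 1 in one place: 3-(trifluoromethyl)phenyl in place of isopropyl on a saturated chain carbon bound to an aromatic carbon. Neither measured step touches this saturated chain carbon, but both show the shared core holding its number while groups on its outer parts are exchanged, and the isobutyl arm itself was swapped without a change beyond the scatter in the step from compound 1 to compound 3. The expected outcome is therefore no step beyond the scatter, expressed as a number 0.07 log units lower from compound 1 to compound 4 (within the scatter). Compound 4 is estimated at 9.4, with a range from 9.05 to 9.75.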

Compound 4, acid dissociation constant: 9.47
Compound 4: middle estimate off by 0.07 log units, on the low side; the range from low to high includes it.
By their numbers in this assay, from the lowest: compounds 3, 1, 2 and 4 (each within the scatter of the next).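

In this assay, putting 3-(trifluoromethyl)phenyl in place of isopropyl on a saturated chain carbon bound to an aromatic carbon gave no change at the digits printed from compound 1 to compound 4 (within the scatter) even though the swap is a large one: 10 heavy atoms, including 3 fluorine and one six-membered aromatic ring of carbon only, enter where 3 carbon atoms leave. Within the data shown here, none of the earlier steps changed what sits on this saturated chain carbon, so this is the first direct reading at this position, and for this one change the read-out does not move beyond the scatter. Nothing available explains this outcome.

Both the leaving and the entering group have no hydrogen-bond donors or acceptors and no net charge, so a single result leaves open whether an amine or a carboxylic acid on this carbon would also leave the number in place. A longer chain in place of isopropyl, without any ring, also remains an open case at this position.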